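The compounds below may be only part of what the source reports. "The series", "measured", "known", "first", "only" and "open" are said of these compounds alone.

Measured so far in the series:

Compound 1 `CC(=O)Nc1nn(-c2ccccc2)c(=O)c2ccccc12`: 52%
Compound 2 `COc1ccc(NC(=O)Nc2nn(-c3ccccc3)c(=O)c3ccccc23)cc1`: 4%
Compound 3 `CC(=O)N(C(C)=O)c1nn(-c2ccccc2)c(=O)c2ccccc12`: 47%

In an assay on CHO cells for displacement of a labelled ligand from adenosine receptor A1 (Homo sapiens), tested at 10 uM (on this read-out lower numbers stand for less inhibition and higher numbers for more inhibition at the one concentration tested (going by the name of the read-out)), compound 2 stands lowest of the three numbers shown, and both gaps to the others are beyond the scatter. The step of a number 48 percentage points lower from compound 1 to compound 2 (beyond the scatter) is the one large movement in the set; the step of a number 5 percentage points lower from compound 1 to compound 3 (within the scatter) stays within the scatter, so compound 1 and compound 3 are not distinguishable on this read-out.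

Compound 4 `Cc1ccc(NC(=O)Nc2nn(-c3ccccc3)c(=O)c3ccccc23)cc1` is the next member. Against compound 2 the change is methyl in place of methoxy on an aromatic carbon. Neither measured step bears on this position: the step from compound 1 to compound 2 replaced the whole methyl by (4-methoxyphenyl)amino, and the step from compound 1 to compound 3 concerned the amide-type nitrogen. Among the compounds with values here, no measured pair varies the substituent on the (4-methoxyphenyl)amino group, so there is no direct guide. With the urea-type linkage kept, and compound 2 already near the floor of the read-out, the expectation is a step that stays within the scatter in this assay, in no particular direction. For compound 4 the estimate in this assay is therefore 8%, with a range of 0% to 25%. This estimate means a step of a number 4 percentage points higher from compound 2 to compound 4 (within the scatter), expected to remain inside the usual scatter.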

Compound 4, a percentage reported as inhibition, at one concentration (the size of the read-out at that concentration, not a potency): 29%
Beside the measured number, compound 4's estimate is 21 percentage points below it; the measured number lies above the stated range.
By their numbers in this assay, from the lowest: compound 2; then compound 4; then compounds 3 and 1 (each within the scatter of the next).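

The substituent on the aromatic carbon para to a large group is not silent in this assay: with the rest of the molecule unchanged, methyl in place of methoxy gives a number 25 percentage points higher from compound 2 to compound 4 (beyond the scatter), a change of one heavy atom and one hydrogen-bond acceptor fewer. The fall that comes with replacing the methyl on the carbonyl carbon of compound 1 therefore depends on the substituent of the aryl ring, since the (4-methylphenyl)amino group gives a number 23 percentage points lower from compound 1 to compound 4 (beyond the scatter) while the (4-methoxyphenyl)amino group gives a number 48 percentage points lower from compound 1 to compound 2 (beyond the scatter). No measurement in hand accounts for this difference between methoxy and methyl.

From the compounds shown here alone, with only two substituents at this position, it remains open whether the oxygen of the methoxy group lowers the number or the methyl group raises it, a question that the unsubstituted phenyl, chloro, hydroxy or ethyl analogues would help to settle. Also open, going by these compounds, is whether the same substituent change behaves alike at other positions of the ring, or when a benzyl group or a simple alkyl amine stands in place of the arylamino group.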